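The compounds below may be only part of what the source reports. "The series", "measured", "known", "first", "only" and "open" are said of these compounds alone.

Compound 1 `COc1ccc(-c2nc(/N=C(\N)n3ccnc3)sc2-c2ccc(OC)cc2)cc1`: > 100 nM. Compound 2 `COc1ccc(-c2nc(CNC(C)=O)sc2-c2ccc(OC)cc2)cc1`: 15 nM. Compound 3 `COc1ccc(-c2nc(CNC(=O)CSc3ccccc3)sc2-c2ccc(OC)cc2)cc1`: < 100 nM.

Three measured compounds share one core and differ only in the group on one aromatic carbon. For the measured compounds named here, in a functional assay with Oryctolagus cuniculus as the target (on this read-out lower numbers stand for stronger inhibition and higher numbers for weaker inhibition), compound 2 gives 15 nM, the only plain number of the three. For compound 1 this assay reports a limit, > 100 nM. For compound 3 this assay likewise reports only a limit, < 100 nM. Consequently the step of an at least 6.6-fold lower number from compound 1 to compound 2 (0.82 log units; beyond the scatter) is known only as a lower bound, and the step that the limit leaves unreadable from compound 2 to compound 3 cannot be sized at all.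

Compound 4 `COc1ccc(-c2nc(C(=O)N=C(N)N)sc2-c2ccc(OC)cc2)cc1` alters compound 2 at the same carbon: a group of 6 heavy atoms (2 carbon, 3 nitrogen, 1 oxygen; no ring) in place of a group of 5 heavy atoms (3 carbon, 1 nitrogen, 1 oxygen; no ring), on an aromatic carbon. Going by the values given here, of the two measured steps, only the one from compound 1 to compound 2 exchanges the whole group at this carbon, so it bears most closely on the new change; the step to compound 3 adds phenylsulfanyl farther out and gives no readable guide. Because an at least 6.6-fold lower number from compound 1 to compound 2 (0.82 log units; beyond the scatter) followed the removal of a group built of carbon and nitrogen in favour of acetamidomethyl, bringing in a group of 2 carbon, 3 nitrogen and 1 oxygen is expected to weaken inhibition moderately rather than strengthen it. Compound 4 is therefore estimated at 45 nM, with a range from 10 nM to 200 nM. This estimate means a 3.0-fold higher number from compound 2 to compound 4 (0.48 log units; beyond the scatter).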

Compound 4, half-maximal inhibitory concentration: > 100 nM
Compound 4: no number, only a limit; the forecaster's own chance of this, stated with the estimate: 30%; at least 2.2-fold (0.34 log units) between middle value and limit.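

In this assay compound 4 gives only a limit, > 100 nM. Even so, the change from acetamidomethyl gives an at least 6.6-fold higher number from compound 2 to compound 4 (0.82 log units; beyond the scatter), so this aromatic carbon, next to the ring nitrogen and next to the ring sulfur, is sensitive to more than the presence of a ring in its group: the group in compound 1 carries a five-membered aromatic ring, while the group in compound 4 has no ring and still gives a clearly weaker result than compound 2. The step between compound 1 and compound 4 cannot be read because both values are limits: the limit of > 100 nM in this assay, at which 2 of the 4 values shown sit.

The compounds shown leave open how much weaker compound 4 really is, and whether the loss follows from the carbonyl attached directly to the aromatic carbon or from the nitrogen-rich end of the group. On these data alone, it also remains open how a simpler group at this carbon, such as aminomethyl or a carboxylic acid, would read out in this assay, which could help separate those two parts.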